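A few compounds are considered here, and "the series" means these few. Any claim that something is new, unique, unknown or untested is made for them only; others in the source may bear on it.

Among the measured compounds shown here, compound 1, with the structure `C=CC[C@H]1C[C@]2([C@@H](C)Cc3ccc(OC)cc3)OCOC2=CC1=O`, is the stronger of the two compounds measured so far: in a functional assay on M14 cells (Homo sapiens) for antiproliferative activity, with a stated time of 72 h (a lower number here means a stronger inhibitor, a higher number a weaker inhibitor), compound 1 gives 20 nM. Compound 2, with the structure `C=CC[C@H]1C[C@]2([C@H](C)Cc3ccc(OC)cc3)OCOC2=CC1=O`, gives 81 nM in this assay, and the step is a 4.1-fold higher number from compound 1 to compound 2 (0.61 log units; beyond the scatter); this follows from the fact that compounds 1 and 2 differ only in the configuration as drawn, since nothing else separates the two.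

Compound 3, with the structure `C=CC[C@H]1C[C@]2([C@@H](C)Cc3ccc(OC(C)=O)cc3)OCOC2=CC1=O`, differs from compound 1 by acetyl in place of methyl on an oxygen on an aromatic ring. For the measured compounds named here, the only measured step, from compound 1 to compound 2, concerns a change in configuration and not a change of group on the aromatic oxygen, so it offers little guidance for this move. Going by the values given here, with no direct precedent, a step within the usual scatter, in either direction, seems the most reasonable expectation. Compound 3 is therefore expected to show a 1.8-fold higher number from compound 1 to compound 3 (0.24 log units; within the scatter) in this assay, with an estimate of 35 nM and a range from 10 nM to 120 nM.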

Compound 3, half-maximal inhibitory concentration: > 20000 nM
Compound 3: only a limit was reported (the forecaster's own chance of this, stated with the estimate: 2%); middle value at least 570-fold (2.75 log units) from the limit.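

The aromatic oxygen proves to be a very sensitive place: acetyl in place of methyl gives an at least 1000-fold higher number from compound 1 to compound 3 (3.00 log units; beyond the scatter) in this assay, a far larger step than the change of configuration, which gave a 4.1-fold higher number from compound 1 to compound 2 (0.61 log units; beyond the scatter). Compound 3 gives > 20000 nM, which is a limit and not a number: the limit of > 20000 nM in this assay, at which 1 of the 3 values shown sits. The step therefore sets only a minimum size, yet it already shows that the methoxy of compound 1 cannot be exchanged for acetoxy without activity passing out of reach of the assay.

The compounds shown do not tell which part of the acetyl accounts for this step, the carbonyl or the added carbon. Going by these compounds, whether a hydroxyl or an ethoxy group in place of the methoxy would keep the activity of compound 1 also remains open.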